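The compounds below may be only part of what the source reports. "The series", "measured", "known", "first", "only" and "open" are said of these compounds alone.

In a functional assay on B16-F10 cells (Mus musculus) for antiproliferative activity, read by CCK-8 assay, with a stated time of 48 h (on this read-out lower numbers stand for stronger inhibition and higher numbers for weaker inhibition), compound 2 (`COc1ccc(/C=C\c2cc(OC)c(OC)c(OC)c2)cc1OCc1ccc(C=O)cc1`) gives 4200 nM and compound 3 (`COc1ccc(/C=C\c2cc(OC)c(OC)c(OC)c2)cc1OCc1ccc(CNCCO)cc1`) gives 6600 nM on the shared core, two values that lie within the scatter of each other. Compound 1 (`COc1ccc(/C=C\c2cc(OC)c(OC)c(OC)c2)cc1OCc1ccc(CNC(C)(C)C(=O)O)cc1`) reads > 10000 nM in this assay and that reading is a limit of the assay, not a number. Compound 3 therefore cannot be told apart from compound 2 on these numbers.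

Compound 4 (`COc1ccc(/C=C\c2cc(OC)c(OC)c(OC)c2)cc1OCc1ccc(CN2CC[C@H](O)C2)cc1`) has not yet been measured. Its difference from compound 3 is 3-hydroxypyrrolidin-1-yl in place of (2-hydroxyethyl)amino on a saturated chain carbon bound to an aromatic carbon in a single place: 3-hydroxypyrrolidin-1-yl in place of (2-hydroxyethyl)amino on a saturated chain carbon bound to an aromatic carbon.

The closest measured change also alters the group on that amine nitrogen: 2-hydroxyethyl in place of 1-carboxy-1-methylethyl gives an at least 1.5-fold lower number from compound 1 to compound 3 (0.18 log units; that floor lies within the scatter) and it rests on a limit. Replacing the whole amine side group gives an at least 2.3-fold lower number from compound 1 to compound 2 (0.37 log units; beyond the scatter) in one case and a 1.6-fold higher number from compound 2 to compound 3 (0.20 log units; within the scatter) in the other.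

Starting from compound 3 at 6600 nM with these small steps, no change beyond the scatter is expected in this assay and no firm direction either. The estimated change is a 1.3-fold lower number from compound 3 to compound 4 (0.12 log units; within the scatter) and it is expected to stay small. For compound 4 the estimated value is 5000 nM with an expected range from 1800 nM to 10000 nM in this assay.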

Compound 4, half-maximal inhibitory concentration: > 10000 nM
Compound 4 ended at the assay's limit; the forecaster's own chance of this, stated with the estimate: 15%; middle value at least 2.0-fold (0.30 log units) away from the limit.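

Closing the open (2-hydroxyethyl)amino group into 3-hydroxypyrrolidin-1-yl, on a saturated chain carbon bound to an aromatic carbon, gives an at least 1.5-fold higher number from compound 3 to compound 4 (0.18 log units; that floor lies within the scatter) in this assay, so the true size of this step remains unknown. Measured from formyl on an aromatic carbon, (3-hydroxypyrrolidin-1-yl)methyl gives an at least 2.3-fold higher number from compound 2 to compound 4 (0.37 log units; beyond the scatter), whereas ((2-hydroxyethyl)amino)methyl gave a 1.6-fold higher number from compound 2 to compound 3 (0.20 log units; within the scatter), so this position can separate one uncharged amine side group from the formyl compound where the earlier one could not. The reading of compound 4 is a limit, as is the reading of compound 1, so the step between them cannot be read: the limit of > 10000 nM in this assay, at which 2 of the 4 values shown sit.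

The compounds shown cannot separate the effect of the ring from that of its hydroxyl, and an unsubstituted pyrrolidine, a piperidine or a morpholine on the same saturated chain carbon would help to tell them apart. Whether the defined stereocentre matters also stays open, since the mirror-image 3-hydroxypyrrolidine is not among the compounds shown here.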